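The source may report more compounds than this note shows. Statements on the series, on what has been measured and on what is new or still open speak of the compounds shown alone.

Working notes on the series. In a functional assay on Caco-2 cells (Homo sapiens) for antiproliferative activity, read by MTT assay, with a stated time of 48 h (a higher number here means a weaker inhibitor, a lower number a stronger inhibitor), compound 1 (`C=CCN(C)C(=O)c1ccc(C(CC)(CC)c2ccc(OCCC(O)(CC)CC)c(C)c2)n1CC`) gives > 50000 nM as a limit of the assay and not a number. Among the measured compounds shown here, compound 2 (`CCn1c(C(=O)N(C)CCO)ccc1C(CC)(CC)c1ccc(OCCC(O)(CC)CC)c(C)c1`) gives 74 nM as the only true number so far. Compound 3 (`CCn1c(C(=O)NC(C)CO)ccc1C(CC)(CC)c1ccc(OCCC(O)(CC)CC)c(C)c1`) has (1-(hydroxymethyl)ethyl)amino in place of (2-hydroxyethyl)(methyl)amino on a carbonyl carbon, so the two have the same atoms, joined differently. For the measured compounds named here, one measured step bears on this, with hydroxymethyl in place of vinyl on a saturated chain carbon bound to an amide-type nitrogen. Compound 3 has hydroxymethyl and no vinyl, so a reversal of that large step beyond the scatter (an at least 670-fold lower number from compound 1 to compound 2 (2.82 log units; beyond the scatter)) is not expected. Going by the values given here, no measured step covers the swap itself, so a modest estimated move to a higher number is expected in this assay (a 2.7-fold higher number from compound 2 to compound 3 (0.43 log units; beyond the scatter)). For compound 3 the estimated value is 200 nM (expected range 30 nM to 2000 nM).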

Compound 3, half-maximal inhibitory concentration: > 50000 nM
Compound 3: only a limit was reported; the forecaster's own chance of this, stated with the estimate: 8%; at least 250-fold (2.39 log units) between middle value and limit.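

With the hydroxyl kept, moving from (2-hydroxyethyl)(methyl)amino to (1-(hydroxymethyl)ethyl)amino on the carbonyl carbon gives an at least 670-fold higher number from compound 2 to compound 3 (2.82 log units; beyond the scatter). In this assay a hydroxymethyl end on this chain is therefore not enough on its own, and how the same atoms are joined decides between a measured number and a limit. Compound 3 gives > 50000 nM, which is a limit and not a number, and the series now rests on a single true number: the limit of > 50000 nM in this assay, at which 2 of the 3 values shown sit.

The step from compound 1 to compound 3 cannot be read, and the compounds shown do not separate the loss of the methyl on the amide nitrogen from the branch in the chain. Going by these compounds, whether (2-hydroxyethyl)amino or the longer (3-hydroxypropyl)(methyl)amino on the same carbonyl carbon would give a number or a limit stays open.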